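This account rests on a few compounds, and the source may have more. Where it says the series, first, only, none or still open, it means among the compounds named here.

Measured compounds:
compound 1 `CN(C)c1ccc(C(=O)N2CCC(NS(=O)(=O)c3cc(S(=O)(=O)c4ccccc4)ccc3C(F)(F)F)CC2)cc1` gives 300 nM in an assay on isolated protein for displacement of a labelled ligand from secreted frizzled-related protein 1 (Homo sapiens), read by fluorescence polarization, with a stated time of 30 min; a lower number here means a stronger inhibitor, a higher number a weaker inhibitor;
compound 2 `O=C(c1cccnc1)N1CCC(NS(=O)(=O)c2cc(S(=O)(=O)c3ccccc3)ccc2C(F)(F)F)CC1` gives 80 nM;
compound 3 `O=S(=O)(NC1CCN(S(=O)(=O)c2ccccc2)CC1)c1cc(S(=O)(=O)c2ccccc2)ccc1C(F)(F)F` gives 130 nM.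

All three share the same core and differ only in the group on the amine nitrogen of the six-membered non-aromatic ring. Compound 3 stands second highest of the three numbers; its nearest neighbour is compound 2, with a 1.6-fold higher number from compound 2 to compound 3 (0.21 log units; within the scatter), and its furthest is compound 1, with a 2.3-fold lower number from compound 1 to compound 3 (0.36 log units; beyond the scatter).

Compound 4 `O=C(O)c1ccc(N2CCC(NS(=O)(=O)c3cc(S(=O)(=O)c4ccccc4)ccc3C(F)(F)F)CC2)cc1` has not been measured. It differs from compound 3 in one place: 4-carboxyphenyl in place of phenylsulfonyl on an amine nitrogen in a ring. The measured steps at this position are a 3.8-fold lower number from compound 1 to compound 2 (0.57 log units; beyond the scatter), a 2.3-fold lower number from compound 1 to compound 3 (0.36 log units; beyond the scatter) and a 1.6-fold higher number from compound 2 to compound 3 (0.21 log units; within the scatter). Every exchange so far at this ring nitrogen has moved the number by a modest amount at most, in either direction. None of the three measured groups is a directly attached aryl ring carrying a carboxylic acid, so the present change is less closely covered than the earlier ones. The expectation for this assay is therefore a step of a 1.5-fold higher number from compound 3 to compound 4 (0.19 log units; within the scatter), small and at most just beyond the scatter, with a wide range to allow for the uncovered change. Compound 4 is estimated at 200 nM, in the range 60 nM to 700 nM.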

Compound 4, half-maximal inhibitory concentration: 120 nM
Compound 4: middle estimate off by 1.7-fold (0.22 log units), on the high side; the range from low to high includes it.
By their numbers in this assay, from the lowest: compounds 2, 4 and 3 (each within the scatter of the next); then compound 1.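

In this assay, a 4-carboxyphenyl attached directly to the amine nitrogen in the ring stands level with phenylsulfonyl (a 1.1-fold lower number from compound 3 to compound 4 (0.03 log units; within the scatter)) and with (pyridin-3-yl)carbonyl (a 1.5-fold higher number from compound 2 to compound 4 (0.18 log units; within the scatter)), so a carbonyl or sulfonyl link at this nitrogen is not needed for a number in this range, and an aryl ring carrying a carboxylic acid is accepted there. Compound 1 remains the only one of the four set apart from the others, with a 2.5-fold lower number from compound 1 to compound 4 (0.40 log units; beyond the scatter), which shows that a carbonyl link alone does not secure a number in this range. Nothing measured here accounts for this equivalence of the three groups.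

Open, going by these compounds, is how much of the value of compound 4 depends on the carboxylic acid, which a plain phenyl, a methyl ester or a primary amide on the same ring would separate from the contribution of the directly attached ring. Also open, on these data alone, is whether a longer chain, such as a carboxymethyl group on that phenyl ring, would hold the number level with compound 2, compound 3 and compound 4 or move it beyond the scatter.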